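A few compounds are considered here, and "the series" means these few. Any claim that something is new, unique, unknown or untested is made for them only; others in the source may bear on it.

In a physicochemical assay for solubility, in phosphate buffer, measured as thermodynamic solubility, at pH 2 (a higher number here means a more soluble compound, a lower number a less soluble compound), compound 1 (`CCC(CC)N1CCN(c2nc3c(c(Nc4ccc(C(F)(F)F)cc4)n2)CCN(c2ncccc2C(F)(F)F)CC3)CC1`) gives 243 ug/mL. Compound 2 (`CNC1CCN(c2nc3c(c(Nc4ccc(C(F)(F)F)cc4)n2)CCN(c2ncccc2C(F)(F)F)CC3)C1`) reads > 220 ug/mL, which is a limit of the assay and not a number. Compound 3 (`CC(=O)NC1CCN(c2nc3c(c(Nc4ccc(C(F)(F)F)cc4)n2)CCN(c2ncccc2C(F)(F)F)CC3)C1`) differs from compound 2 by acetyl in place of methyl on an amine nitrogen. Among the measured compounds shown here, the only measured step is a step that the limit leaves unreadable from compound 1 to compound 2, so it offers no size to carry over, and no measured step covers this change. On judgement alone, the estimated move is downward, expected as an at least 1.8-fold lower number from compound 2 to compound 3 (0.26 log units; that floor lies within the scatter). In this assay, compound 3 is expected at 120 ug/mL, with an estimated range from 30 ug/mL to 350 ug/mL.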

Compound 3, solubility: 202 ug/mL
Estimate against measurement, compound 3: 1.7-fold (0.23 log units) below; measured number inside the range.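

In this assay, acetyl in place of methyl on the amine nitrogen gives an at least 1.0-fold lower number from compound 2 to compound 3 (0.03 log units; that floor lies within the scatter), which is only a floor. Compound 2 reads > 220 ug/mL, which is a limit, so the full size of that step cannot be read: the limit of > 220 ug/mL in this assay, at which 1 of the 3 values shown sits.

At the aromatic carbon, 3-acetamidopyrrolidin-1-yl in place of 4-(pentan-3-yl)piperazin-1-yl gives the first readable step, a 1.2-fold lower number from compound 1 to compound 3 (0.08 log units; within the scatter), and it lies within the scatter.

On these data alone, how far the change from methyl to acetyl reaches beyond its floor stays open. So does how propanoyl or methanesulfonyl in place of acetyl on that amine nitrogen would read in this assay.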